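Furan Replaces Nitrophenyl on the Enone of Compound 2

This account rests on a few compounds, and the source may have more. Where it says the series, first, only, none or still open, it means among the compounds named here.

Measured compounds:
compound 1 `COc1ccc(-c2cc3ccccc3nc2/C=C/C(=O)c2c(OC)cccc2OC)cc1` gives 4470 nM in a functional assay on H184B5F5/M10 cells (Homo sapiens) for antiproliferative activity, read by XTT assay, with a stated time of 72 h; a lower number here means a stronger inhibitor, a higher number a weaker inhibitor
compound 2 `COc1ccc(-c2cc3ccccc3nc2/C=C/C(=O)c2ccc([N+](=O)[O-])cc2)cc1` gives 6100 nM in this assay

Both measured compounds share the same core and differ only in the aryl group on the carbonyl carbon. Of the two, compound 2 sits at the upper end of the numbers, and compound 1 is separated from it only by a 1.4-fold higher number from compound 1 to compound 2 (0.14 log units; within the scatter), so the two are not distinguishable in this assay.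

Compound 3 `COc1ccc(-c2cc3ccccc3nc2/C=C/C(=O)c2ccco2)cc1` is not yet measured. It differs from compound 2 by furan-2-yl in place of 4-nitrophenyl on a carbonyl carbon. For the measured compounds named here, the only measured step that bears on this position is the one from compound 1 to compound 2, an exchange of aryl groups on the same carbonyl carbon, which stayed within the scatter. On that basis the exchange for furan-2-yl is expected to move the number in this assay by no more than the scatter, in no particular direction, as a 1.2-fold lower number from compound 2 to compound 3 (0.09 log units; within the scatter). Compound 3 is therefore estimated at 5000 nM, within a range of 1500 nM to 16000 nM.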

Compound 3, half-maximal inhibitory concentration: 6240 nM
Beside the measured number, compound 3's estimate is 1.2-fold (0.10 log units) below it; the range from low to high includes it.
By their numbers in this assay, from the lowest: compounds 1, 2 and 3 (each within the scatter of the next).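

In this assay the furan-2-yl compound gives a 1.0-fold higher number from compound 2 to compound 3 (0.01 log units; within the scatter) and, against the other aryl group, a 1.4-fold higher number from compound 1 to compound 3 (0.14 log units; within the scatter) so that both steps stay within the scatter. For the compounds shown here, this shows that the carbonyl carbon whose other neighbour is the double-bonded chain carbon accepts more than the six-membered aromatic rings of carbon only seen in the earlier compounds: a five-membered aromatic ring with 1 hetero atom, of 5 heavy atoms in place of the 9 of 4-nitrophenyl, leaves the number indistinguishable from those of compound 1 and compound 2. Across the three aryl groups shown, neither ring size nor the presence of the nitro group separates the compounds in this measurement, and no information is available to explain why the numbers stay together.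

The compounds shown leave open whether any group on this carbonyl carbon can move the number beyond the scatter, for example a saturated cyclohexyl ring, a longer alkyl chain, or an aryl group carrying an amine or a carboxylic acid. All three compounds also share one core, so whether this insensitivity to the aryl group holds on a different core remains an open question.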